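From 2-phenoxyethoxy to benzyloxy: working notes

The compounds below may be only part of what the source reports. "The series", "measured", "known", "first", "only" and "open" are said of these compounds alone.

Measured in an ADME assay on RAW264.7 cells (Mus musculus) for cytotoxicity, read by MTT assay, with a stated time of 24 h, in the presence of a further agent that is not named here (on this read-out higher numbers stand for weaker inhibition and lower numbers for stronger inhibition), so far
- compound 1 (`COCCOc1ccc(C(O)C2OC(=O)c3c(OC)cc(OC)cc32)cc1`) gives > 40000 nM as a limit
- compound 2 (`COc1cc(OC)c2c(c1)C(C(O)c1ccc(OCCOc3ccccc3)cc1)OC2=O`) gives > 40000 nM as a limit

Compound 2 stands at > 40000 nM in this assay and this is a limit, not a number. Compound 3 (`COc1cc(OC)c2c(c1)C(C(O)c1ccc(OCc3ccccc3)cc1)OC2=O`) has phenyl in place of phenoxymethyl on a saturated chain carbon bound to an oxygen on an aromatic ring and so carries benzyloxy instead of 2-phenoxyethoxy. For the measured compounds named here, the one measured step (a step that the two limits leave unreadable from compound 1 to compound 2) offers no size to carry over. The other evidence is the limit of > 40000 nM in this assay, at which 2 of the 2 values shown sit, and nothing more. No step beyond the scatter is expected in this assay, in either direction, and the expected step is a number no higher from compound 2 to compound 3 (the limit leaves the size open) in this estimate. A report of only a limit is the likeliest expected outcome for compound 3. The estimate for compound 3 is 40000 nM with an expected range from 20000 nM to 80000 nM on this read-out.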

Compound 3, half-maximal inhibitory concentration: > 40000 nM
Compound 3: a limit, no number (the forecaster's own chance of this, stated with the estimate: 85%); the middle value sits exactly at the limit.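

In this assay compound 3 gives > 40000 nM, a limit and not a number. For the compounds shown here, no step among compound 1, compound 2 and compound 3 can be read. The compounds shown leave open whether 2-phenoxyethoxy and benzyloxy differ at all on this read-out.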